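The source may report more compounds than this note shows. Statements on the series, on what has been measured and on what is new or still open speak of the compounds shown alone.

Compound 2, with structure `CN(C)c1ccc(/C=C(/SCc2ccc(Cl)cc2)C(=O)c2ccc(Cl)cc2)cc1`, stands at the edge of the measured numbers: in a functional assay on DU-145 cells (Homo sapiens) for inhibition, read by trypan blue exclusion, with a stated time of 96 h (on this read-out lower numbers stand for stronger inhibition of growth and higher numbers for weaker inhibition of growth), compound 2 gives only a limit, > 100000 nM, and no number. Compound 1, with structure `CSc1ccc(/C=C(/SCc2ccc(Cl)cc2)C(=O)c2ccc(Cl)cc2)cc1`, gives 25000 nM in this assay. Compound 3, with structure `COc1ccccc1/C=C(/SCc1ccc(Cl)cc1)C(=O)c1ccc(Cl)cc1`, differs from compound 2 in one place: 2-methoxyphenyl in place of 4-(dimethylamino)phenyl on a double-bonded chain carbon bound to a double-bonded chain carbon. Within the data shown here, only one measured step bears on the change, an at least 4.0-fold higher number from compound 1 to compound 2 (0.60 log units; beyond the scatter), and it runs into (the limit of > 100000 nM in this assay, at which 1 of the 2 values shown sits), so its full size is unknown. That step shows that replacing the group on the aryl ring moved the number out of range, while compound 1 with methylsulfanyl gave a measurable 25000 nM. The change to 2-methoxyphenyl is therefore expected to bring a number back into range, with compound 3 expected to sit at an at least 2.5-fold lower number from compound 2 to compound 3 (0.39 log units; beyond the scatter). Compound 3 is estimated at 40000 nM in this assay, within 10000 nM to 100000 nM.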

Compound 3, concentration for 50% growth inhibition: 1000 nM
The estimate for compound 3 lay 40-fold (1.60 log units) above the measured number; measured number outside the range, below it.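

At this position, on a double-bonded chain carbon bound to a double-bonded chain carbon, the choice of aryl group moves the number much further than compounds 1 and 2 alone showed: in this assay, the change to 2-methoxyphenyl gives an at least 100-fold lower number from compound 2 to compound 3 (2.00 log units; beyond the scatter). Compound 2 gives only a limit, so that step has no full size: the limit of > 100000 nM in this assay, at which 1 of the 3 values shown sits.

The comparison between two measured numbers confirms a large change, as 2-methoxyphenyl in place of 4-(methylsulfanyl)phenyl gives a 25-fold lower number from compound 1 to compound 3 (1.40 log units; beyond the scatter).

Compound 3 differs from compound 1 and compound 2 both in the group on the ring and in its place there, so the compounds shown do not separate these two changes. As far as these compounds go, it remains open how a 4-methoxyphenyl group or a 2-(methylsulfanyl)phenyl group would read at this carbon.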